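The source may report more compounds than this note shows. Statements on the series, on what has been measured and on what is new or still open speak of the compounds shown alone.

Values in a functional assay on brain (Rattus norvegicus, strain Wistar) for inhibition; on this read-out lower numbers stand for stronger inhibition and higher numbers for weaker inhibition:
- compound 1 `Cc1[nH]c(=O)n(C)c1-c1ccc(OCCC(C)C)cc1`: 6600 nM
- compound 2 `CCCCCCCOc1ccc(-c2c(C)[nH]c(=O)n2C)cc1`: 5700 nM

Compound 2, at 5700 nM, stands within the scatter of compound 1. The next analogue, compound 3 `CCCCCCCCOc1ccc(-c2c(C)[nH]c(=O)n2C)cc1`, is not yet measured and differs from compound 2 by methyl in place of hydrogen on a saturated chain carbon, seven bonds along the chain from an oxygen on an aromatic ring. Within the data shown here, one measured step bears on this, a change in the same chain: a 1.2-fold lower number from compound 1 to compound 2 (0.06 log units; within the scatter), with pentyl in place of isopropyl. That step stays within the scatter, so no step beyond the scatter is expected in this assay. The expected change is a 1.1-fold lower number from compound 2 to compound 3 (0.06 log units; within the scatter). Compound 3 is estimated at 5000 nM, with an expected range of 2500 nM to 10000 nM.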

Compound 3, half-maximal inhibitory concentration: 4000 nM
Compound 3: middle estimate off by 1.3-fold (0.10 log units), on the high side; the measured number falls inside the stated range.
By their numbers in this assay, from the lowest: compounds 3, 2 and 1 (each within the scatter of the next).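

In this assay the methyl in place of hydrogen, seven bonds along the chain from an oxygen on an aromatic ring, gives a 1.4-fold lower number from compound 2 to compound 3 (0.15 log units; within the scatter) and so leaves the number within the scatter. Hexyl in place of isopropyl, two bonds along the chain from that oxygen, gives a 1.7-fold lower number from compound 1 to compound 3 (0.22 log units; within the scatter) and also stays within the scatter, so all three chains read alike in this assay. No measured evidence bears on these results. Still open, going by these compounds, is whether a longer chain, an amine or a carboxylic acid in place of these chains would give a step beyond the scatter.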